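A Thioether Step in Growth Inhibition

A few compounds are considered here, and "the series" means these few. Any claim that something is new, unique, unknown or untested is made for them only; others in the source may bear on it.

In a functional assay on DU-145 cells (Homo sapiens) for inhibition, read by trypan blue exclusion, with a stated time of 96 h (on this read-out lower numbers stand for stronger inhibition of growth and higher numbers for weaker inhibition of growth), compound 1 (`COc1ccc(/C=C(\C(=O)c2ccc(Br)cc2)S(=O)(=O)c2ccc(Br)cc2)c(F)c1`) gives 10000 nM and compound 2 (`O=C(/C(=C\c1ccc(I)cc1)Sc1ccc(Br)cc1)c1ccc(Br)cc1`) gives 1000 nM as the lower of the two numbers, a gap beyond the scatter. Compared with compound 2, compound 3 (`COc1ccc(/C=C(/Sc2ccc(Br)cc2)C(=O)c2ccc(Br)cc2)c(F)c1`) carries 2-fluoro-4-methoxyphenyl in place of 4-iodophenyl (2-fluoro-4-methoxyphenyl in place of 4-iodophenyl on a double-bonded chain carbon bound to a double-bonded chain carbon) on a double-bonded chain carbon bound to a double-bonded chain carbon. Going by the values given here, no measured step speaks directly to this swap, so in this assay only a small weakening is expected, perhaps none beyond the scatter. The estimated change is a step (a 2.0-fold higher number from compound 2 to compound 3 (0.30 log units; within the scatter)) toward a higher number. For compound 3 the expected value is 2000 nM (estimated range from 500 nM to 8000 nM).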

Compound 3, concentration for 50% growth inhibition: 20000 nM
For compound 3 the middle estimate is 10-fold (1.00 log units) below the measured one; measured number above the stated range.
By their numbers in this assay, from the lowest: compound 2; then compounds 1 and 3 (each within the scatter of the next).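

In this assay, 2-fluoro-4-methoxyphenyl in place of 4-iodophenyl on a double-bonded chain carbon bound to a double-bonded chain carbon is a large step (a 20-fold higher number from compound 2 to compound 3 (1.30 log units; beyond the scatter)), so this place responds strongly to the change of aryl group. With 2-fluoro-4-methoxyphenyl present, (4-bromophenyl)sulfanyl in place of (4-bromophenyl)sulfonyl does not separate the two compounds (a 2.0-fold higher number from compound 1 to compound 3 (0.30 log units; within the scatter)). No measurement given here accounts for either result.

From the compounds shown here alone, whether the loss of iodine or the entry of fluorine and methoxy carries the large step stays open, and a 4-methoxyphenyl or 2-fluorophenyl group at this place could separate them. Going by these compounds, whether (4-bromophenyl)sulfonyl would also match (4-bromophenyl)sulfanyl alongside 4-iodophenyl also stays open.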